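A few compounds are considered here, and "the series" means these few. Any claim that something is new, unique, unknown or untested is made for them only; others in the source may bear on it.

In a functional assay on PC-3 cells (Homo sapiens) for cytotoxicity, read by MTT assay, with a stated time of 72 h (on this read-out lower numbers stand for stronger inhibition and higher numbers for weaker inhibition), compound 1 `COc1cccc(/C=C/C(=O)Nc2cc(OC)c(OC)c(OC)c2)c1` gives 2100 nM, compound 2 `COc1ccc(C(=O)c2cc(OC)c(OC)c(OC)c2)cc1NC(=O)/C=C/c1cc(OC)c(OC)c(OC)c1` gives 3900 nM, and compound 3 `COc1ccc(C(=O)c2cc(OC)c(OC)c(OC)c2)cc1NC(=O)/C=C/c1ccc(OC)c(OC)c1` gives 7500 nM. Compound 3 holds the highest of the three numbers; its nearest neighbour is compound 2, and a 1.9-fold higher number from compound 2 to compound 3 (0.28 log units; within the scatter) arose from hydrogen in place of methoxy on an aromatic carbon. Compound 1 stands beyond the scatter from compound 3, at a clearly lower number.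

Compound 4 `COc1ccc(C(=O)c2cc(OC)c(OC)c(OC)c2)cc1NC(=O)/C=C/c1ccc(F)cc1` differs from compound 3 by 4-fluorophenyl in place of 3,4-dimethoxyphenyl on a double-bonded chain carbon bound to a double-bonded chain carbon, that is, 2-(3,4-dimethoxyphenyl)ethenyl becomes 2-(4-fluorophenyl)ethenyl. For the measured compounds named here, only the step from compound 2 to compound 3 bears on this change, and that step, the loss of one methoxy, stayed within the scatter. Going by the values given here, no measured pair shows the loss of both methoxy groups or the entry of fluorine, so the expectation rests on that single small step. A further small rise in this assay is therefore expected, not clearly beyond the scatter, as a 1.3-fold higher number from compound 3 to compound 4 (0.10 log units; within the scatter). For compound 4 the estimated value is 9500 nM, with a range from 3000 nM to 30000 nM.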

Compound 4, half-maximal inhibitory concentration: 3200 nM
For compound 4 the middle estimate is 3.0-fold (0.47 log units) above the measured one, within the range that was stated.
By their numbers in this assay, from the lowest: compounds 1, 4, 2 and 3 (each within the scatter of the next, the first and the last beyond it).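

The change to 4-fluorophenyl on a double-bonded chain carbon bound to a double-bonded chain carbon brought a 2.3-fold lower number from compound 3 to compound 4 (0.37 log units; beyond the scatter) in this assay, whereas the earlier loss of a single methoxy had stayed within the scatter. Measured against 3,4,5-trimethoxyphenyl at the same place, the change gave a 1.2-fold lower number from compound 2 to compound 4 (0.09 log units; within the scatter), so among these compounds a ring without any methoxy group reads level with the one carrying three, and the number does not simply follow the methoxy count. Nothing available explains either step.

Whether the fluorine or the absence of the methoxy groups accounts for the step remains open. A plain phenyl group, or a phenyl carrying chlorine or an amine, at this place would be needed to separate the two.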